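Phenyl on the Ring Amide Nitrogen of Compound 1

The source may report more compounds than this note shows. Statements on the series, on what has been measured and on what is new or still open speak of the compounds shown alone.

Compound 1 `O=C1NNC(=O)C2(CSC3=C2C(=O)c2ncccc2C3=O)N1` has the highest of the two numbers recorded in a functional assay on SF-268 cells (Homo sapiens) for antiproliferative activity, read by MTT assay, with a stated time of 96 h; on this read-out higher numbers stand for weaker inhibition and lower numbers for stronger inhibition: compound 1 gives 4820 nM. Compound 2 `Cc1ccc(N2C(=O)NC3(CSC4=C3C(=O)c3ncccc3C4=O)C2=O)cc1` is its nearest neighbour, and in this assay compound 2 gives 660 nM, a gap beyond the usual scatter. Compound 3 `O=C1NN(c2ccccc2)C(=O)C2(CSC3=C2C(=O)c2ncccc2C3=O)N1` differs from compound 1 in one place: phenyl in place of hydrogen on an amide-type nitrogen in a ring. Within the data shown here, no measured pair shows this change directly. A step toward a lower number is expected, a 3.2-fold lower number from compound 1 to compound 3 (0.51 log units; beyond the scatter), partly because compound 2 gives 660 nM. Compound 3 is estimated at 1500 nM, with a likely range from 500 nM to 4500 nM.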

Compound 3, half-maximal inhibitory concentration: 2200 nM
Compound 3: the middle estimate sits 1.5-fold (0.17 log units) below what was measured; the measured number falls inside the stated range.
By their numbers in this assay, from the lowest: compound 2; then compound 3; then compound 1.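

In this assay, the amide-type nitrogen of the core of compound 1 carries a phenyl in place of hydrogen without loss of activity, giving a measured step for this change (a 2.2-fold lower number from compound 1 to compound 3 (0.34 log units; beyond the scatter)). Among these compounds, this is the first direct reading of the change at this position, and it is a modest one. No measurement shown accounts for the step. The compounds shown leave open whether methyl on this nitrogen would give a similar step. They also leave open how a phenyl bearing an amine or a carboxylic acid would read here.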